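The compounds below may be only part of what the source reports. "The series", "measured", "known", "first", "only" and "open" are said of these compounds alone.

Measured so far in an assay on HEK293 cells for agonist activity at transient receptor potential cation channel subfamily M member 8 (Homo sapiens), read by fluorescence and calcium flux, with a stated time of 15 min; a higher number here means that more compound is needed for the effect, a lower number that less compound is needed:
compound 1 `Cc1ccc(OCC(=O)N(Cc2cccs2)c2c[nH]nc2C)cc1` gives 0.4 nM;
compound 2 `Cc1ccc(OCC(=O)N(Cc2cccs2)CC(C)C)cc1` gives 900 nM;
compound 3 `Cc1ccc(OCC(=O)N(CCO)Cc2cccs2)cc1` gives 900 nM.

Compound 3 stands level with compound 2 at the digits recorded, the two together forming the high end of the three numbers; its one gap of note is to compound 1, seen as a 2300-fold higher number from compound 1 to compound 3 (3.35 log units; beyond the scatter). Compound 4 `Cc1ccc(OCC(=O)N(Cc2cccs2)c2c(C)n[nH]c2C)cc1` differs from compound 3 in one place: 3,5-dimethyl-1H-pyrazol-4-yl in place of 2-hydroxyethyl on an amide-type nitrogen. The step bearing on this is a 2300-fold higher number from compound 1 to compound 3 (3.35 log units; beyond the scatter), read here in the reverse direction, with a 2300-fold higher number from compound 1 to compound 2 (3.35 log units; beyond the scatter) as a second instance of the same pattern. Both point to a large fall in this assay once the amide-type nitrogen again carries a methyl-substituted 1H-pyrazol-4-yl group. Compound 4 is therefore expected near 1 nM, between 0.2 nM and 6 nM, the expected step being a 900-fold lower number from compound 3 to compound 4 (2.95 log units; beyond the scatter).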

Compound 4, half-maximal effective concentration: 0.3 nM
The estimate for compound 4 lay 3.3-fold (0.52 log units) above the measured number; low and high end bracket the measured number.
By their numbers in this assay, from the lowest: compounds 4 and 1 (each within the scatter of the next); then compounds 2 and 3 (each within the scatter of the next).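

With 3,5-dimethyl-1H-pyrazol-4-yl on the amide-type nitrogen, this assay shows a 3000-fold lower number from compound 3 to compound 4 (3.48 log units; beyond the scatter) and a 3000-fold lower number from compound 2 to compound 4 (3.48 log units; beyond the scatter), so the large fall seen with 3-methyl-1H-pyrazol-4-yl recurs with a second methyl-substituted pyrazolyl group. Methyl in place of hydrogen on an aromatic carbon of that group leaves the number within the scatter, with a 1.3-fold lower number from compound 1 to compound 4 (0.12 log units; within the scatter). No supporting data bear on why these pyrazolyl groups differ so far from the open chains. Open, as far as these compounds go, is whether an unsubstituted 1H-pyrazol-4-yl or a phenyl ring on the same nitrogen would keep so low a number.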